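The source may hold more compounds than are shown below. What is called first, only, known or untested is meant among the compounds shown, and "the series" means these compounds.

The set covers three measured compounds and one still to be tested. Compound 1 `CCN(CC)CCCNc1nc(-c2ccc(NC(=O)Nc3ccccc3Cl)cc2)nc2c(Cl)c(Cl)sc12` and compound 3 `CCN(CC)CCCNc1nc(-c2ccc(NC(=O)Nc3ccc(C)cc3)cc2)nc2c(Cl)c(Cl)sc12` share one core, while compound 2 `CCN(CC)CCCNc1nc(-c2ccc(NC(=O)Nc3ccccc3Cl)cc2)nc2ccsc12` and compound 4 `CCN(CC)CCCNc1nc(-c2ccc(NC(=O)Nc3ccc(C)cc3)cc2)nc2ccsc12` share another; the difference between the two cores is not broken down here.

In a functional assay on MKN-45 cells (Homo sapiens) for cytotoxicity, read by MTT assay, with a stated time of 72 h (on this read-out lower numbers stand for stronger inhibition and higher numbers for weaker inhibition), compound 1 gives 1450 nM. Compound 3 gives 3320 nM in this assay. Compound 2 gives 390 nM in this assay, the lowest of the three numbers, with compound 1 nearest and compound 3 furthest from it.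

Within the first core, the change from compound 1 to compound 3 is 4-methylphenyl in place of 2-chlorophenyl on an amide-type nitrogen. That step brought a 2.3-fold higher number from compound 1 to compound 3 (0.36 log units; beyond the scatter). The change from compound 2 to compound 4 is 4-methylphenyl in place of 2-chlorophenyl on an amide-type nitrogen, the same change made on the second core, with the same surroundings at the place where it happens.

Among the compounds with values here, only one measured example of this change exists, so the expectation for compound 4 rests on that single step of compound 1 to compound 3 together with the starting point of compound 2. A step of comparable size is expected for compound 4, that is a 2.3-fold higher number from compound 2 to compound 4 (0.36 log units; beyond the scatter), estimated from the earlier 2.3-fold higher number from compound 1 to compound 3 (0.36 log units; beyond the scatter) and from compound 2 at 390 nM. Compound 4 is thus expected to give about 900 nM in this assay, with the estimate spanning from 450 nM to 1800 nM.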

Compound 4, half-maximal inhibitory concentration: 1760 nM
The estimate for compound 4 lay 2.0-fold (0.29 log units) below the measured number; the measured number falls inside the stated range.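

On the core of compound 2, 4-methylphenyl in place of 2-chlorophenyl on the amide-type nitrogen gave a 4.5-fold higher number from compound 2 to compound 4 (0.65 log units; beyond the scatter) in this assay, and this step agrees with the one on the other core: the same change on two cores in this assay, a 2.3-fold higher number (0.36 log units; beyond the scatter) from compound 1 to compound 3 and a 4.5-fold higher number (0.65 log units; beyond the scatter) from compound 2 to compound 4, 2.0-fold (0.29 log units) apart, within the scatter of two such steps. On these two cores, then, the change carried over: it moved the number the same way on both, and the two sizes cannot be told apart. Within the data shown here, this rests on only two pairs, however, so it does not show that the change would carry over to any further core, that other changes on this nitrogen would behave in the same way, or why the number rises.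

The change also alters both the substituent and its place on the ring at once, so the compounds shown leave open whether the higher number follows from losing the chlorine or from the new position, a question that 4-chlorophenyl and 2-methylphenyl groups on the same nitrogen would separate. They also leave open whether the step would hold if a morpholine replaced the diethylamino end of the side chain.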